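One added methoxy on compound 2

This account rests on a few compounds, and the source may have more. Where it says the series, first, only, none or still open, it means among the compounds named here.

Compound 1 `COc1ccccc1/C=C/C(=O)OC/C=C/c1cc(OC)c(OC)cc1OC`: 39 mg/kg
Compound 2 `COc1cc(OC)c(OC)cc1/C=C/COC(=O)/C=C/c1ccc(OC)c(OC)c1`: 58.1 mg/kg
Compound 3 `COc1cc(OC)c(OC)cc1/C=C/COC(=O)/C=C/c1ccccc1C(F)(F)F`: 85.7 mg/kg

In a functional assay on the whole organism (strain Kunming) with Mus musculus as the target, with a stated time of 0.5 h (on this read-out higher numbers stand for an effect only at larger amounts of compound and lower numbers for an effect already at smaller amounts), compound 2 (58.1 mg/kg) lies within the scatter of both other compounds. Only the outer pair separates, modestly (a 2.2-fold higher number from compound 1 to compound 3 (0.34 log units; beyond the scatter)). Compound 4 `COc1cc(OC)c(OC)cc1/C=C/COC(=O)/C=C/c1cc(OC)c(OC)c(OC)c1` has methoxy in place of hydrogen on an aromatic carbon. For the measured compounds named here, no measured step makes exactly this change. The closest one also alters the methoxy groups on that aromatic ring (a 1.5-fold higher number from compound 1 to compound 2 (0.17 log units; within the scatter)), and the replacement of that whole ring by 2-(trifluoromethyl)phenyl is no larger (a 1.5-fold higher number from compound 2 to compound 3 (0.17 log units; within the scatter)). No step beyond the scatter is therefore expected in this assay, and the expected step is small (a 1.1-fold lower number from compound 2 to compound 4 (0.02 log units; within the scatter)). Compound 4 is estimated at 55 mg/kg, with an expected range from 28 mg/kg to 105 mg/kg.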

Compound 4, dose for half-maximal effect: 33.2 mg/kg
Compound 4: the middle estimate sits 1.7-fold (0.22 log units) above what was measured; the range from low to high includes it.
By their numbers in this assay, from the lowest: compounds 4, 1, 2 and 3 (each within the scatter of the next, the first and the last beyond it).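

In this assay methoxy in place of hydrogen on this aromatic carbon, ortho to a methoxy group, can now be read as a single change, and it stays within the scatter (a 1.8-fold lower number from compound 2 to compound 4 (0.24 log units; within the scatter)). For the compounds shown here, the earlier steps touched this ring only through wider changes, so this is the first direct reading of the added group alone. Nothing at hand bears on a reason for this result. As far as these compounds go, it remains open whether an amine, a hydroxy group or a longer alkoxy chain on the same aromatic carbon would also stay within the scatter.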